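Swapping bromo for benzyloxy on the core of compound 2

The compounds below may be only part of what the source reports. "The series", "measured", "known", "first", "only" and "open" are said of these compounds alone.

Of the compounds shown here, three have been measured in a functional assay on A549 cells (Homo sapiens) for inhibition, tested at 100 uM; a higher number here means a stronger effect of the compound at the concentration tested, a lower number a weaker effect. Compound 2 `Cc1ccc(S(=O)(=O)n2cc(-c3cc(C(F)(F)F)ccn3)c3cc(Br)ccc32)cc1` gives 98%, the highest of the three numbers. Compound 1 `Cc1ccc(S(=O)(=O)n2cc(-c3cc(C(F)(F)F)c(C#N)c(-c4cn(S(=O)(=O)c5ccc(C)cc5)c5ccc(Br)cc45)n3)c3cc(Br)ccc32)cc1` gives 70.6%, which sits beyond the scatter below compound 2, and compound 3 `Cc1ccc(S(=O)(=O)n2cc(-c3cc(C(F)(F)F)cc(-c4cn(S(=O)(=O)c5ccc(C)cc5)c5cc(Br)ccc45)n3)c3ccc(Br)cc32)cc1` gives 49.2%, the furthest below, also beyond the scatter. For the measured compounds named here, compounds 1 and 3 each differ from compound 2 in more than one place, so no single-change step between measured compounds is available to guide the next comparison.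

Compound 4 `Cc1ccc(S(=O)(=O)n2cc(-c3cc(C(F)(F)F)ccn3)c3cc(OCc4ccccc4)ccc32)cc1` is compound 2 with one change: benzyloxy in place of bromo on an aromatic carbon. The change sits on the fused ring of the shared core, where a small halogen is replaced by a larger group carrying an added aromatic ring and one hydrogen-bond acceptor. Going by the values given here, with no measured step of this kind on record, the expectation rests only on the high starting point of compound 2 in this assay and on the size of the alteration. The estimated step of a number 18 percentage points lower from compound 2 to compound 4 (beyond the scatter) is a moderate fall, plausibly beyond the scatter. Compound 4 is accordingly expected to reach about 80%, with a range from 50% to 98%.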

Compound 4, a percentage reported as inhibition, at one concentration (the size of the read-out at that concentration, not a potency): 35.9%
For compound 4 the middle estimate is 44.1 percentage points above the measured one; measured number outside the range, below it.
By their numbers in this assay, from the lowest: compound 4; then compound 3; then compound 1; then compound 2.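

For the compounds shown here, replacing bromo with benzyloxy gives the first change in this assay that can be read at a single place on the shared core: the effect is a number 62.1 percentage points lower from compound 2 to compound 4 (beyond the scatter) and counts as large. This aromatic carbon therefore matters to the read-out, since this one change alone costs compound 4 most of the inhibition seen with compound 2. The swap adds an oxygen and an aromatic ring together, so this single step cannot separate their contributions, and no measurement on hand explains the fall.

Still open, from the compounds shown here alone, is whether the loss follows the whole benzyloxy group or only part of it, which a methoxy group or a phenyl ring at this carbon could help to separate. Going by these compounds, it is also open whether a chloro group or an amine here would stay close to compound 2.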